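Fluoro added to the core of compound 2

The compounds below may be only part of what the source reports. "The series", "measured", "known", "first", "only" and "open" are said of these compounds alone.

Measured so far in a functional assay on HEK293 cells with Glucose-dependent insulinotropic receptor (Homo sapiens) as the target, read by cAMP accumulation, with a stated time of 60 min; on this read-out higher numbers stand for larger maximal responses and lower numbers for smaller maximal responses:
compound 1 `CCCS(=O)(=O)N1CC=C(c2ccc3c(c2)CC(C2CCN(c4ncc(Cl)cn4)CC2)O3)CC1` gives 88%;
compound 2 `CCCc1cnc(N2CCC(C3Cc4cc(C5=CCN(S(=O)(=O)CCC)CC5)ccc4O3)CC2)nc1` gives 107%;
compound 3 `CCCc1cnc(N2CCC(C3Cc4cc(C5CCN(S(=O)(=O)CCC)CC5)ccc4O3)CC2)nc1` gives 43%.

Compound 2 stands highest of the three: its step to compound 1 and its step to compound 3 are both beyond the scatter. Compound 4 `CCCc1cnc(N2CCC(C3Cc4c(ccc(C5=CCN(S(=O)(=O)CCC)CC5)c4F)O3)CC2)nc1` is not yet measured. It differs from compound 2 in one place: fluoro in place of hydrogen on an aromatic carbon.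

The two measured steps concern other parts of the molecule. The change of a number 19 percentage points higher from compound 1 to compound 2 (beyond the scatter) was a modest rise, and the change of a number 64 percentage points lower from compound 2 to compound 3 (beyond the scatter) was a large fall. Going by the values given here, neither step places a fluoro on the core, so no measured step bears directly on the change from compound 2 to compound 4. With nothing pointing either way, the estimate for compound 4 in this assay is a step of a number 7 percentage points lower from compound 2 to compound 4 (within the scatter), within the scatter. The expected value for compound 4 is therefore 100%, in a range from 70% to 120%.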

Compound 4, largest response reached (Emax), in percent of the reference or control that the assay uses: 123%
Beside the measured number, compound 4's estimate is 23 percentage points below it, outside the stated range (above it).
By their numbers in this assay, from the lowest: compound 3; then compound 1; then compound 2; then compound 4.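

In this assay, fluoro in place of hydrogen on an aromatic carbon of the shared core gives a number 16 percentage points higher from compound 2 to compound 4 (beyond the scatter). The earlier steps shown here changed the group on the far aromatic ring and the ring carrying the sulfonyl group; this step shows that the core itself also affects the maximal response, and that this carbon, ortho to a large group, can carry a fluoro without any loss of response. Nothing available here explains the rise.

A single fluoro cannot show whether the rise is special to fluorine, so a methoxy group or a nitrile on the same carbon remains an open case. As far as these compounds go, it is also open whether the same fluoro would raise the response in the chloro series of compound 1 or the saturated series of compound 3.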